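This account rests on a few compounds, and the source may have more. Where it says the series, first, only, none or still open, it means among the compounds named here.

Working notes on the series. Compound 1 `CC(C)CCC(=O)Nc1ccn([C@H]2CC[C@H](O)[C@@H](C)O2)c(=O)n1` is the parent with a free hydroxyl on the core; in a functional assay on HCT-116 cells (Homo sapiens) for cytotoxicity, read by sulforhodamine B assay, with a stated time of 24 h (on this read-out higher numbers stand for weaker inhibition and lower numbers for stronger inhibition), compound 1 gives > 20000 nM, which is a limit of the assay and not a number. Compound 1 therefore stands only at the edge of what this assay reports (the limit of > 20000 nM in this assay, at which 1 of the 3 values shown sits). Compound 2 `CC(C)CCC(=O)Nc1ccn([C@H]2CC[C@H](O[C@H]3O[C@H](C)[C@@H](N(C)C)[C@H](O)[C@H]3O)[C@@H](C)O2)c(=O)n1` and compound 3 `CC(C)/C=C/C(=O)Nc1ccn([C@H]2CC[C@H](O[C@H]3O[C@H](C)[C@@H](N(C)C)[C@H](O)[C@H]3O)[C@@H](C)O2)c(=O)n1` carry an additional ring on that hydroxyl position; in this assay compound 2 gives 390 nM, and in this assay compound 3 gives 780 nM. Among the compounds with values here, the one measured step, a 2.0-fold higher number from compound 2 to compound 3 (0.30 log units; within the scatter), exchanges only the group on the carbonyl carbon and falls within the scatter.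

Compound 4 `CC(C)C(=O)Nc1ccn([C@H]2CC[C@H](O)[C@@H](C)O2)c(=O)n1` is the next to be measured. It differs from compound 1 by isopropyl in place of isopentyl on a carbonyl carbon. Within the data shown here, no measured step touches this pair directly; the single step in hand alters the group on the carbonyl carbon of compound 2 and compound 3, where the extra ring is present, and that alteration moved the number little. Nothing in hand suggests that this change on compound 1 brings the number into the measurable range, so the expected step is a step that the limit leaves unreadable from compound 1 to compound 4, that is, none beyond the scatter, with a limit again the most likely outcome. For compound 4 the estimate in this assay is 30000 nM, with a range from 15000 nM to 100000 nM.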

Compound 4, half-maximal inhibitory concentration: > 20000 nM
Compound 4: a limit, no number; the forecaster's own chance of this, stated with the estimate: 80%; the middle value does not contradict the limit.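

In this assay compound 4 gives > 20000 nM, a limit of the assay and not a number, so no step between compound 1 and compound 4 can be read: the limit of > 20000 nM in this assay, at which 2 of the 4 values shown sit.

The compounds shown leave open what isopropyl in place of isopentyl on a carbonyl carbon does when the additional ring of compound 2 and compound 3 is present.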